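Methyl addition in a cytotoxic oxadiazole series

The source may report more compounds than this note shows. Statements on the series, on what has been measured and on what is new or still open speak of the compounds shown alone.

Compound 1 `c1ccc(CNC(c2ccc[nH]2)c2nnc(-c3ccccc3)o2)cc1` in a functional assay on A549 cells (Homo sapiens) for cytotoxicity, read by MTT assay, with a stated time of 24 h (a lower number here means a stronger inhibitor, a higher number a weaker inhibitor), gives 187000 nM. Compound 2 `Brc1ccc(-c2nnc(C(NCc3ccccc3)c3ccc[nH]3)o2)cc1` differs from it by bromo in place of hydrogen on an aromatic carbon and gives 87200 nM, the step being a 2.1-fold lower number from compound 1 to compound 2 (0.33 log units; beyond the scatter). Compound 3 `Cc1ccc(-c2nnc(C(NCc3ccccc3)c3ccc[nH]3)o2)cc1` differs from compound 1 by methyl in place of hydrogen on an aromatic carbon; in this assay compound 3 gives 745000 nM, with a 4.0-fold higher number from compound 1 to compound 3 (0.60 log units; beyond the scatter); between compound 2 and compound 3 the step is an 8.5-fold higher number from compound 2 to compound 3 (0.93 log units; beyond the scatter). Compound 4 `Cc1ccc(CNC(c2ccc[nH]2)c2nnc(-c3ccc(Br)cc3)o2)cc1`, not yet measured, differs from compound 2 by methyl in place of hydrogen on an aromatic carbon, the same change as that from compound 1 to compound 3, made on the core of compound 2. Within the data shown here, because a 4.0-fold higher number from compound 1 to compound 3 (0.60 log units; beyond the scatter) was seen once, a similar step is expected, a 3.4-fold higher number from compound 2 to compound 4 (0.54 log units; beyond the scatter), though the single precedent leaves this uncertain. Compound 4 is estimated at 300000 nM in this assay, between 100000 nM and 900000 nM.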

Compound 4, half-maximal inhibitory concentration: 53900 nM
The estimate for compound 4 lay 5.6-fold (0.75 log units) above the measured number, outside the stated range (below it).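

With the core of compound 2, methyl in place of hydrogen stays within the scatter in this assay, a 1.6-fold lower number from compound 2 to compound 4 (0.21 log units; within the scatter), so the step seen on the core of compound 1 does not carry over. The two steps differ: the same change on two cores in this assay, a 4.0-fold higher number (0.60 log units; beyond the scatter) from compound 1 to compound 3 and a 1.6-fold lower number (0.21 log units; within the scatter) from compound 2 to compound 4, 6.4-fold (0.81 log units) apart, beyond the scatter of two such steps What this does not show is a reason for the difference: the methyl stands on the benzyl group in compound 4 and on the other six-membered aromatic ring in compound 3, so core and site change together, and a single pair on each core sets no rule for the series.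

Still open, on these data alone, is how methyl on the benzyl group reads without the bromo. Also open, as far as these compounds go, is whether a methoxy, a chloro or an amine at that place on the benzyl group gives a step beyond the scatter.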